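Oral bioavailability notes: compound 2 towards compound 3

The source may hold more compounds than are shown below. What is called first, only, known or untested is meant among the compounds shown, and "the series" means these compounds.

In an ADME assay on the whole organism (Mus musculus, strain CD-1) for pharmacokinetics, at a dose of 10 mg/kg by the oral route (a higher number here means that a larger share of the oral dose reaches the circulation, a lower number that a smaller share of the oral dose reaches the circulation), compound 2 `COc1cc([C@](O)(CCN(C)C)[C@@H](c2cc3cc(C#N)ccc3nc2OC)c2cccc(OC)c2F)cc(SC)n1` gives 28%, and compound 1 `COc1cc([C@](O)(CCN(C)C)[C@@H](c2cc3cc(Br)ccc3nc2OC)c2cccc(OC)c2F)cc(SC)n1` gives 31%. Within the data shown here, these are the only two numbers so far. Among the measured compounds shown here, the one measured step is a number 3 percentage points lower from compound 1 to compound 2 (within the scatter), so the two numbers stand level and compound 2 has no separate place of its own on this scale.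

Compound 3 `CCSc1cc([C@](O)(CCN(C)C)[C@@H](c2cc3cc(C#N)ccc3nc2OC)c2cccc(OC)c2F)cc(SCC)n1` keeps the cyano group of compound 2 and differs elsewhere: a group of 12 heavy atoms (9 carbon, 1 nitrogen, 2 sulfur; one six-membered aromatic ring with 1 hetero atom) in place of a group of 10 heavy atoms (7 carbon, 1 nitrogen, 1 oxygen, 1 sulfur; one six-membered aromatic ring with 1 hetero atom), on a saturated chain carbon bound to an oxygen on a saturated carbon and two saturated chain carbons. For the measured compounds named here, no measured step touches the group exchanged here, so the data give no direct size for this change. Going by the values given here, the single step available concerns a different part of the structure and serves only as a loose guide. The expectation therefore starts from compound 2 at 28%, with a wide range left open for an exchange that has not been tested in this series. No step beyond the scatter is expected in this assay, and the estimated step is a number 3 percentage points lower from compound 2 to compound 3 (within the scatter). For compound 3 the expected value is 25%, with an estimated range of 11% to 42%.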

Compound 3, oral bioavailability: 24%
Compound 3: the middle estimate sits 1 percentage points above what was measured, within the range that was stated.
By their numbers in this assay, from the lowest: compounds 3, 2 and 1 (each within the scatter of the next).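

In this assay, among these compounds, the exchange of a group of 12 heavy atoms (9 carbon, 1 nitrogen, 2 sulfur; one six-membered aromatic ring with 1 hetero atom) for a group of 10 heavy atoms (7 carbon, 1 nitrogen, 1 oxygen, 1 sulfur; one six-membered aromatic ring with 1 hetero atom) gives a number 4 percentage points lower from compound 2 to compound 3 (within the scatter), the first direct reading at this place, on a saturated chain carbon bound to an oxygen on a saturated carbon and two saturated chain carbons. The series thus has a measured step here as well as the cyano-for-bromo step, and this larger exchange also leaves the two numbers level on this scale. No measurement in hand bears on why the number stays level under this exchange.

The group is exchanged as a whole, so this single step cannot assign any share of the result to the individual atoms that differ within it. Still open, as far as these compounds go, is whether a group at this same place carrying an amine, a carboxylic acid or a longer chain would stay level in this assay or move beyond the scatter.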